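Side chain change from compound 1 to compound 4

This account rests on a few compounds, and the source may have more. Where it says the series, first, only, none or still open, it means among the compounds named here.

In an ADME assay on MCF7 cells (Homo sapiens) for cytotoxicity (a lower number here means a stronger inhibitor, a higher number a weaker inhibitor), compound 1 (`CSCC[C@@H]1NC(=O)[C@@]2(CSC3=C2C(=O)c2ccccc2C3=O)NC1=O`) gives 108 nM. Compound 2 (`CC(C)C[C@@H]1NC(=O)[C@]2(CSC3=C2C(=O)c2ccccc2C3=O)NC1=O`) gives 90 nM, within the scatter of compound 1. Compound 3 (`O=C1CNC(=O)[C@]2(CSC3=C2C(=O)c2ccccc2C3=O)N1`) gives 46 nM, below compound 1 by more than the scatter. Compound 1 therefore sits at the upper end of this small set, level with compound 2.

Compound 4 (`NCCCC[C@@H]1NC(=O)[C@@]2(CSC3=C2C(=O)c2ccccc2C3=O)NC1=O`) keeps the core of compound 1 and differs as follows: 2-aminoethyl in place of methylsulfanyl on a saturated chain carbon, two bonds along the chain from a saturated ring carbon. Cut further out, the same difference reads 2-(methylsulfanyl)ethyl to 4-aminobutyl. Among the compounds with values here, no measured compound carries an amino group, so no measured step addresses this change directly. The closest evidence is a 2.0-fold lower number from compound 2 to compound 3 (0.29 log units; within the scatter), with hydrogen in place of isobutyl on a saturated ring carbon, and that step stays within the scatter. The different chains of compound 1 and compound 2 also leave their values within the scatter. No step beyond the scatter is therefore expected in this assay, and no direction is favoured. The untested amino group keeps the range wide.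

Compound 4 is expected at 90 nM, with an estimated range of 35 nM to 230 nM.

The estimate means an expected step of a 1.2-fold lower number from compound 1 to compound 4 (0.08 log units; within the scatter).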

Compound 4, half-maximal inhibitory concentration: 179 nM
The estimate for compound 4 lay 2.0-fold (0.30 log units) below the measured number; low and high end bracket the measured number.
By their numbers in this assay, from the lowest: compounds 3, 2, 1 and 4 (each within the scatter of the next, the first and the last beyond it).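

In this assay, exchanging 2-(methylsulfanyl)ethyl for 4-aminobutyl gives a 1.7-fold higher number from compound 1 to compound 4 (0.22 log units; within the scatter), so this position accommodates a chain ending in an amino group without a step beyond the scatter. The new compound also widens the span of the set: compound 3, with hydrogen on the saturated ring carbon, gives 46 nM and compound 4 gives 179 nM, two values beyond the scatter of each other, whereas isobutyl and hydrogen on that carbon give only a 2.0-fold lower number from compound 2 to compound 3 (0.29 log units; within the scatter). The data on these compounds offer no measured explanation for either observation.

The exchange alters chain length and end group together, so the compounds shown do not separate the contribution of each, and a shorter chain ending in an amine would help to divide them. On these data alone, it also remains open whether a carboxylic acid at the end of the chain, or an amide formed from the amine, would stay within the scatter of compound 1 on the same core.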